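Pyrazole amide series: step from compound 1 to compound 4

This account rests on a few compounds, and the source may have more. Where it says the series, first, only, none or still open, it means among the compounds named here.

Working notes. In an assay on Sf9 cells for inhibition of histone-lysine N-methyltransferase EZH2 variant Y641N (Homo sapiens), read by scintillation counting, in the presence of a further agent that is not named here (on this read-out higher numbers stand for weaker inhibition and lower numbers for stronger inhibition), compound 1 `Nc1ncnc2c1ncn2[C@@H]1O[C@H](CSCC[C@H](N)C(=O)NCc2cnn(-c3ccc(F)cc3)c2)[C@@H](O)[C@H]1O` gives 600 nM, the lowest of the two numbers recorded; compound 2 `Nc1ncnc2c1ncn2[C@@H]1O[C@H](CSCC[C@H](N)C(=O)NCc2cc3n(n2)CCN(Cc2ccccc2)C3)[C@@H](O)[C@H]1O` gives 2800 nM, a higher number beyond the scatter. In this assay compound 3 `Cn1nc(CNC(=O)[C@@H](N)CCSC[C@H]2O[C@@H](n3cnc4c(N)ncnc43)[C@H](O)[C@@H]2O)cc1C1CCC1` gives "not determined" (no result reported), so no result is available for it. Compound 4 `Nc1ncnc2c1ncn2[C@@H]1O[C@H](CSCC[C@H](N)C(=O)NCc2cc(C3CCC3)[nH]n2)[C@@H](O)[C@H]1O` differs from compound 1 by a group of 9 heavy atoms (7 carbon, 2 nitrogen; one four-membered non-aromatic ring of carbon only, one five-membered aromatic ring with 2 hetero atoms) in place of a group of 12 heavy atoms (9 carbon, 2 nitrogen, 1 fluorine; one five-membered aromatic ring with 2 hetero atoms, one six-membered aromatic ring of carbon only), on a saturated chain carbon bound to an amide-type nitrogen. Among the compounds with values here, no pair of measured compounds shares only this change, so the size of the step is open; compound 2 carries a different group on this carbon and merely shows that changes here can weaken inhibition. A modest weakening, close to the scatter, is expected from compound 1 to compound 4, a 1.7-fold higher number from compound 1 to compound 4 (0.22 log units; within the scatter). For compound 4 the value in this assay is estimated at 1000 nM, within 300 nM to 3000 nM.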

Compound 4, half-maximal inhibitory concentration: 1000 nM
Beside the measured number, compound 4's estimate shows no gap at the digits printed; the measured number falls inside the stated range.
By their numbers in this assay, from the lowest: compounds 1 and 4 (each within the scatter of the next); then compound 2.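

In this assay, the step on the saturated chain carbon bound to an amide-type nitrogen reads a 1.7-fold higher number from compound 1 to compound 4 (0.22 log units; within the scatter) and so shows that this place tolerates the group with the four-membered carbon ring in exchange for the group with the six-membered aromatic carbon ring and fluorine. No available measurement bears on the reason for this result. Open, going by these compounds, is whether an amine or a carboxylic acid on the four-membered ring keeps inhibition in this range. The separate contributions of the ring and the fluorine also remain unresolved.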